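Tetrazole series: methoxy in place of ethyl on compound 3

The source may hold more compounds than are shown below. What is called first, only, known or untested is meant among the compounds shown, and "the series" means these compounds.

Among the compounds with values here, compound 3 `CCc1cccc2cc(-c3nn[nH]n3)cnc12` holds the only number in a functional assay on the whole organism (strain Sprague-Dawley) for inhibition, with Rattus norvegicus as the target (on this read-out higher numbers stand for an effect only at larger amounts of compound and lower numbers for an effect already at smaller amounts), giving 2.5 mg/kg. Compound 1 `CCc1cccc2cc(C(=O)O)cnc12` returns > 50 mg/kg, which is a limit of this assay and not a number. Compound 2 `Cc1cccc2cc(C(=O)O)cnc12` returns > 50 mg/kg, likewise a limit. Because of the limit of > 50 mg/kg in this assay, at which 2 of the 3 values shown sit, there is a step that the two limits leave unreadable from compound 1 to compound 2. The ring change gives an at least 20-fold lower number from compound 1 to compound 3 (1.30 log units; beyond the scatter). Compound 4 `COc1cccc2cc(-c3nn[nH]n3)cnc12` differs from compound 3 by methoxy in place of ethyl on an aromatic carbon. Within the data shown here, no measured step swaps ethyl for methoxy on the aromatic carbon, and the one step on the ethyl chain is unreadable. The step of a 1.2-fold higher number from compound 3 to compound 4 (0.08 log units; within the scatter) is therefore expected to stay within the scatter. Compound 4 is estimated at 3 mg/kg in this assay, in the range 1 mg/kg to 10 mg/kg.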

Compound 4, minimum effective dose: 2.5 mg/kg
For compound 4 the middle estimate is 1.2-fold (0.08 log units) above the measured one; measured number inside the range.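

In this assay, within the data shown here, methoxy in place of ethyl on this aromatic carbon gives no change at the digits printed from compound 3 to compound 4 (within the scatter), the first readable step at this position. Swapping a carbon for an oxygen and adding a hydrogen-bond acceptor thus leaves the number within the scatter in the tetrazole compounds. The only earlier change at this position, on the ethyl chain of the carboxy compounds, cannot be read: the limit of > 50 mg/kg in this assay, at which 2 of the 4 values shown sit.

Still open, going by these compounds, is whether an amine, a chlorine atom or a longer chain on this carbon would hold the number. Also open, on these data alone, is whether plain hydrogen there would do the same.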